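Cyanomethyl oximes on a sulfide and a sulfone core

This account rests on a few compounds, and the source may have more. Where it says the series, first, only, none or still open, it means among the compounds named here.

Compound 1 `C/C(=N\O)c1ccc(Sc2ncc([C@@]3(C)COC(C)(C)O3)s2)cc1` and compound 2 `C/C(=N\O)c1ccc(S(=O)(=O)c2ncc([C@@]3(C)COC(C)(C)O3)s2)cc1` share the oxime and dioxolane ends but differ in their cores; that difference between the two cores is not broken down here. In a functional assay on blood for inhibition of Polyunsaturated fatty acid 5-lipoxygenase (Homo sapiens) (on this read-out lower numbers stand for stronger inhibition and higher numbers for weaker inhibition), compound 1 gives 130 nM, while compound 2 gives 200 nM; the two lie within the scatter of one another. Compound 3 `C/C(=N\OCC#N)c1ccc(Sc2ncc([C@@]3(C)COC(C)(C)O3)s2)cc1` carries the change cyanomethyl in place of hydrogen on an oxygen on the core of compound 1; in this assay compound 3 gives 30 nM, a step of a 4.3-fold lower number from compound 1 to compound 3 (0.64 log units; beyond the scatter). Compound 4 `C/C(=N\OCC#N)c1ccc(S(=O)(=O)c2ncc([C@@]3(C)COC(C)(C)O3)s2)cc1` carries the same change cyanomethyl in place of hydrogen on an oxygen on the core of compound 2. Because compound 1 moved by a 4.3-fold lower number from compound 1 to compound 3 (0.64 log units; beyond the scatter), a similar step is expected for compound 4, about a 4.0-fold lower number from compound 2 to compound 4 (0.60 log units; beyond the scatter). The estimate for compound 4 in this assay is therefore 50 nM, between 20 nM and 150 nM.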

Compound 4, half-maximal inhibitory concentration: 120 nM
The estimate for compound 4 lay 2.4-fold (0.38 log units) below the measured number; the range from low to high includes it.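

In this assay, hydroxy to cyanomethoxy on the second core gives a 1.7-fold lower number from compound 2 to compound 4 (0.22 log units; within the scatter). Set beside the same change on the first core, the two steps do not separate: the same change on two cores in this assay, a 4.3-fold lower number (0.64 log units; beyond the scatter) from compound 1 to compound 3 and a 1.7-fold lower number (0.22 log units; within the scatter) from compound 2 to compound 4, 2.6-fold (0.41 log units) apart, within the scatter of two such steps. Among these compounds, the pair therefore gives no firm ground for saying that the change behaves differently on the two cores, but it does not show that the change carries over at the same size, since only two steps are at hand and one of them stays within the scatter.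

Still open, going by these compounds, is whether other groups on the oxime oxygen, such as methyl, a longer chain ending in a nitrile or a carboxylic acid, behave alike on both cores. Also open, on these data alone, is whether the change carries to any further core.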